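A few compounds are considered here, and "the series" means these few. Any claim that something is new, unique, unknown or untested is made for them only; others in the source may bear on it.

Compound 3 `COc1cccc(CNCCCNc2ccnc3cc(Oc4ccc(C(C)(C)C)cc4)ccc23)c1O` stands highest of the three compounds measured in an ADME assay for permeability, using PAMPA, with a stated time of 30 min, at pH 7.4 (a lower number here means that the compound crosses the layer more slowly, a higher number that the compound crosses the layer faster), giving 317 10^-6 cm/s. Compound 1 `COc1cccc(CNCCCNc2ccnc3cc(Cc4ccccc4)ccc23)c1O` gives 23 10^-6 cm/s and compound 2 `COc1cccc(CNCCCNc2ccnc3cc(CC4CCCCC4)ccc23)c1O` gives 23 10^-6 cm/s in this assay, with no change at the digits printed from compound 1 to compound 2 (within the scatter). Compound 4 `COc1cccc(CNCCCNc2ccnc3cc(Cc4cc(C)cc(C)c4)ccc23)c1O` differs from compound 3 by 3,5-dimethylbenzyl in place of 4-(tert-butyl)phenoxy on an aromatic carbon. The measured steps that bear on this change run in the opposite direction: a 14-fold higher number from compound 1 to compound 3 (1.14 log units; beyond the scatter) and a 14-fold higher number from compound 2 to compound 3 (1.14 log units; beyond the scatter), both large. Compound 4 thus moves back toward the benzyl-type substituent of compound 1 and compound 2, so a large fall in this assay is expected for compound 4. Among the measured compounds shown here, the two methyl groups on the entering ring have no measured counterpart here, so the full size of the reversal is uncertain. The expected step is a 7.9-fold lower number from compound 3 to compound 4 (0.90 log units; beyond the scatter), giving for compound 4 an estimate of 40 10^-6 cm/s with a range from 15 10^-6 cm/s to 120 10^-6 cm/s in this assay.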

Compound 4, apparent permeability: 23 10^-6 cm/s
The estimate for compound 4 lay 1.7-fold (0.24 log units) above the measured number, and the stated range covers the measured number.
By their numbers in this assay, from the lowest: compounds 1, 2 and 4 (each within the scatter of the next); then compound 3.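

Replacing 4-(tert-butyl)phenoxy with 3,5-dimethylbenzyl on this aromatic carbon gives a 14-fold lower number from compound 3 to compound 4 (1.14 log units; beyond the scatter) in this assay. The two methyl groups on the benzyl ring bring no change at the digits printed from compound 1 to compound 4 (within the scatter), and the cyclohexylmethyl comparison likewise shows no change at the digits printed from compound 2 to compound 4 (within the scatter). Among these four compounds, only compound 3, with its oxygen-linked ring, stands apart, and the three carbon-linked groups sit level.

Going by these compounds, a 3,5-dimethylphenoxy or a 4-(tert-butyl)benzyl group would separate the oxygen link from the tert-butyl group, so which of the two carries the step remains open. No evidence at hand explains the step.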